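Swapping the phenyl group on the amine nitrogen

The source may report more compounds than this note shows. Statements on the series, on what has been measured and on what is new or still open speak of the compounds shown alone.

Measured in a functional assay on ECa-109 cells for inhibition, with ECa-109 cell line (Homo sapiens) as the target, read by sulforhodamine B assay; a higher number here means a weaker inhibitor, a lower number a stronger inhibitor:
Compound 1 `O=C1C(NC2CCCC2)=CC(=O)c2c1nc1n2[C@H]2OC[C@@H](O)[C@H]2OC1`: > 16000 nM (a limit)
Compound 2 `Cc1ccc(NC2=CC(=O)c3c(nc4n3[C@H]3OC[C@@H](O)[C@H]3OC4)C2=O)cc1C`: 4090 nM

Within the data shown here, compound 2 holds the only true number so far. Compound 1 gives > 16000 nM, which is a limit of the assay and not a number. Among the measured compounds shown here, the single measured step, made by putting 3,4-dimethylphenyl in place of cyclopentyl on an amine nitrogen, is an at least 3.9-fold lower number from compound 1 to compound 2 (0.59 log units; beyond the scatter). Its size rests on (the limit of > 16000 nM in this assay, at which 1 of the 2 values shown sits).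

For the measured compounds named here, compound 3 `COc1ccccc1NC1=CC(=O)c2c(nc3n2[C@H]2OC[C@@H](O)[C@H]2OC3)C1=O` keeps the shared core and changes only that group: 2-methoxyphenyl in place of 3,4-dimethylphenyl on an amine nitrogen. Here 2-methoxyphenyl takes the place of 3,4-dimethylphenyl on an amine nitrogen.

The measured step helps only loosely, since it replaced cyclopentyl, whereas this change replaces one substituted phenyl ring with another. Going by the values given here, no measured step shows such a swap, so only a small change is expected in this assay, with a slight lean towards a higher number. The expected step is a 1.2-fold higher number from compound 2 to compound 3 (0.09 log units; within the scatter). For compound 3 the estimate is 5000 nM, with an expected range from 1800 nM to 14000 nM.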

Compound 3, half-maximal inhibitory concentration: > 4000 nM
Compound 3 gave a limit, no number; the forecaster's own chance of this, stated with the estimate: 15%; the middle value is on the limit's open side.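

In this assay compound 3 gives > 4000 nM, which is a limit and not a number. The steps to compound 3 from compound 1 and from compound 2 therefore cannot be read. The compounds shown leave open whether 2-methoxyphenyl on the amine nitrogen gives a weaker, similar or stronger inhibitor than the 3,4-dimethylphenyl of compound 2.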